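The source may report more compounds than this note shows. Statements on the series, on what has been measured and on what is new or still open speak of the compounds shown alone.

Measured compounds:
- compound 1, `CCCCCOCNc1n[n+]([O-])c2ccccc2[n+]1[O-]`, a functional assay on A549 cells (Homo sapiens) for cytotoxicity, read by MTT assay, with a stated time of 72 h; on this read-out higher numbers stand for weaker inhibition and lower numbers for stronger inhibition: 2900 nM
- compound 2, `[O-][n+]1nc(NCOCc2ccc(C(F)(F)F)cc2)[n+]([O-])c2ccccc21`, in this assay compound 2 gives 4270 nM
- compound 3, `COc1ccc(COCNc2n[n+]([O-])c3ccccc3[n+]2[O-])cc1`, in this assay compound 3 gives 3320 nM

The three numbers sit close together. Compound 3 stands second highest of the three; its nearest neighbour is compound 1 and its furthest is compound 2, and both gaps are within the scatter, so no order among them can be claimed. The step of a 1.1-fold higher number from compound 1 to compound 3 (0.06 log units; within the scatter) exchanged butyl for 4-methoxyphenyl on a saturated chain carbon bound to an oxygen on a saturated carbon without effect beyond the scatter, and a 1.3-fold lower number from compound 2 to compound 3 (0.11 log units; within the scatter) was likewise flat.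

Compound 4, `CC(C)CCOCNc1n[n+]([O-])c2ccccc2[n+]1[O-]`, is not yet measured. It differs from compound 3 as follows: isobutyl in place of 4-methoxyphenyl on a saturated chain carbon bound to an oxygen on a saturated carbon. The step that bears on it is a 1.1-fold higher number from compound 1 to compound 3 (0.06 log units; within the scatter), taken in reverse, since it too swaps an alkyl chain against 4-methoxyphenyl at the same place; it was within the scatter. No step beyond the scatter is therefore expected in this assay, in either direction.

For compound 4 the expected value is 3000 nM, with a range from 1500 nM to 6500 nM. This expectation corresponds to a step of a 1.1-fold lower number from compound 3 to compound 4 (0.04 log units; within the scatter).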

Compound 4, half-maximal inhibitory concentration: 2110 nM
Estimate against measurement, compound 4: 1.4-fold (0.15 log units) above; measured number inside the range.
By their numbers in this assay, from the lowest: compounds 4, 1, 3 and 2 (each within the scatter of the next, the first and the last beyond it).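

In this assay, a 1.6-fold lower number from compound 3 to compound 4 (0.20 log units; within the scatter) removes the aromatic ring and the hydrogen-bond acceptor of 4-methoxyphenyl in favour of isobutyl, and the change stays within the scatter, so this place accepts a branched alkyl group as well as the straight chain and the aryl groups seen before. With isopropyl in place of propyl on a saturated chain carbon, two bonds along the chain from an oxygen on a saturated carbon, a 1.4-fold lower number from compound 1 to compound 4 (0.14 log units; within the scatter) is also within the scatter, so branching of the chain gives no readable change here. No accompanying measurement bears on these results.

The compounds shown leave open whether an amine, a carboxylic acid or a much longer alkyl chain at this place would move the number beyond the scatter. They also leave open whether changes to the shared core would count for more than changes at this place.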